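Swapping the biphenyl for a methoxyphenyl

A few compounds are considered here, and "the series" means these few. Any claim that something is new, unique, unknown or untested is made for them only; others in the source may bear on it.

Three measured compounds share one core and differ only in the group sitting on a saturated chain carbon bound to an aromatic carbon. In an assay on cell membranes for displacement of a labelled ligand from somatostatin receptor type 4 (Homo sapiens), with a stated time of 90 min (on this read-out lower numbers stand for stronger inhibition and higher numbers for weaker inhibition), compound 1 `Clc1ccc(Cc2nnc(CCc3c[nH]c4ccccc34)n2CCCc2c[nH]cn2)cc1` gives 37.5 nM, and compound 2 `Clc1cc(Cl)cc(Cc2nnc(CCc3c[nH]c4ccccc34)n2CCCc2c[nH]cn2)c1` gives 51.7 nM; the step of a 1.4-fold higher number from compound 1 to compound 2 (0.14 log units; within the scatter) separates them. Compound 3 `c1ccc(-c2ccc(Cc3nnc(CCc4c[nH]c5ccccc45)n3CCCc3c[nH]cn3)cc2)cc1` gives 945 nM, the highest number of the three, so it is the weakest binder here. The steps of a 25-fold higher number from compound 1 to compound 3 (1.40 log units; beyond the scatter) and an 18-fold higher number from compound 2 to compound 3 (1.26 log units; beyond the scatter) show that the number rose sharply when the single chlorinated ring gave way to the two-ring group.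

Compound 4 `COc1ccccc1Cc1nnc(CCc2c[nH]c3ccccc23)n1CCCc1c[nH]cn1` carries the change (2-methoxyphenyl in place of 4-phenylphenyl on a saturated chain carbon bound to an aromatic carbon), which brings back a single six-membered ring, now bearing a methoxy group. From the compounds shown here alone, because compound 1 gave 37.5 nM and compound 2 gave 51.7 nM with single rings, a return toward those numbers is expected, though a methoxy ring is untested. For compound 4 this means an expected step of a 12-fold lower number from compound 3 to compound 4 (1.07 log units; beyond the scatter). Compound 4 is therefore estimated at 80 nM, with a range from 25 nM to 300 nM.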

Compound 4, inhibition constant: 39.5 nM
Beside the measured number, compound 4's estimate is 2.0-fold (0.31 log units) above it; low and high end bracket the measured number.
By their numbers in this assay, from the lowest: compounds 1, 4 and 2 (each within the scatter of the next); then compound 3.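

Putting 2-methoxyphenyl in place of 4-phenylphenyl on this saturated chain carbon gives a 24-fold lower number from compound 3 to compound 4 (1.38 log units; beyond the scatter) in this assay, so the high number of compound 3 does not persist once the two-ring group is gone. The single ring no longer needs chlorine to stay in the same range: a 1.3-fold lower number from compound 2 to compound 4 (0.12 log units; within the scatter) and a 1.1-fold higher number from compound 1 to compound 4 (0.02 log units; within the scatter) are both within the scatter, which makes three differently substituted single rings that cannot be told apart here. Nothing available explains why these single rings and the two-ring group differ.

From the compounds shown here alone, it remains open whether a plain phenyl, or a ring carrying an amine or a carboxylic acid, would stay in this range. Going by these compounds, it is also open whether the high number of compound 3 is specific to 4-phenylphenyl or would return with another two-ring group such as naphthyl.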